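Benzoyl to pyridinoyl amide in the A3 series

The source may report more compounds than this note shows. Statements on the series, on what has been measured and on what is new or still open speak of the compounds shown alone.

Of the compounds shown here, three have been measured in an assay on CHO cells for displacement of a labelled ligand from adenosine receptor A3 (Homo sapiens), read by scintillation counting, with a stated time of 60 min; a higher number here means a weaker inhibitor, a lower number a stronger inhibitor. Compound 1 `Cc1nc(NC(=O)c2ccccc2)c2nn(-c3ccccc3)cc2n1` gives 5.6 nM in this assay, the lowest of the three numbers. Compound 2 `O=C(c1ccco1)N(C(=O)c1ccco1)c1nc(-c2ccccc2)nc2cn(-c3ccccc3)nc12` gives 75 nM and compound 3 `COc1ccc(-n2cc3nc(-c4ccccc4)nc(NC(C)=O)c3n2)cc1` gives 98 nM, both lying beyond the usual scatter away from compound 1, so compound 1 is the strongest inhibitor of the three measured.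

Compound 4 `Cc1nc(NC(=O)c2cccnc2)c2nn(-c3ccccc3)cc2n1` has not been measured in this assay. It differs from compound 1 in one place: pyridin-3-yl in place of phenyl on a carbonyl carbon, with one hydrogen-bond acceptor entering the amide substituent. Among the measured compounds shown here, no pair of measured compounds isolates this change, so no measured step is available for comparison. The expectation is a small shift toward a weaker inhibitor, of a size that may not exceed the scatter, written as a 2.1-fold higher number from compound 1 to compound 4 (0.33 log units; beyond the scatter). Compound 4 is therefore estimated at 12 nM in this assay, with a range from 4 nM to 40 nM.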

Compound 4, inhibition constant: 5.3 nM
Beside the measured number, compound 4's estimate is 2.3-fold (0.35 log units) above it; the range from low to high includes it.
By their numbers in this assay, from the lowest: compounds 4 and 1 (each within the scatter of the next); then compounds 2 and 3 (each within the scatter of the next).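

Pyridin-3-yl in place of phenyl on a carbonyl carbon gives a 1.1-fold lower number from compound 1 to compound 4 (0.02 log units; within the scatter) in this assay, the first reading in this series that isolates a single place. At this position, an aromatic ring with one hetero atom and one hydrogen-bond acceptor reads level with the all-carbon ring, so compound 1 and compound 4 cannot be told apart here. Nothing measured on these compounds gives a reason for this result.

Going by these compounds, whether pyridin-2-yl or pyridin-4-yl on the same carbonyl carbon would also read level remains open, as does the outcome with a ring carrying an amine or a carboxylic acid. Compound 2 and compound 3 differ from compound 1 in more than one place, so the roles of the other groups on the core also remain unresolved.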